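A few compounds are considered here, and "the series" means these few. Any claim that something is new, unique, unknown or untested is made for them only; others in the source may bear on it.

Measured so far in a functional assay on HL-60 cells (Homo sapiens) for cytotoxicity, read by WST assay, with a stated time of 48 h; a higher number here means that more compound is needed for the effect, a lower number that less compound is needed:

compound 1 `CCCCOc1ccccc1C[C@H]1C(=O)OC[C@@H]1Cc1ccccc1` gives 20000 nM
compound 2 `CCCCCCCOc1ccccc1C[C@H]1C(=O)OC[C@@H]1Cc1ccccc1` gives 75000 nM
compound 3 `CCCCOc1ccc(C[C@H]2C(=O)OC[C@@H]2Cc2ccccc2)cc1` gives 23000 nM

Compound 1 and compound 2 share one core; compound 3 is built on a second core, and the difference between the two cores is not broken down here. In this assay compound 3 and compound 1 lie within the scatter of each other, so no order between them is read.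

Within the first core, compound 2 differs from compound 1 by propyl in place of hydrogen on a saturated chain carbon, four bonds along the chain from an oxygen on an aromatic ring, and this change gave a 3.8-fold higher number from compound 1 to compound 2 (0.57 log units; beyond the scatter).

Compound 4 `CCCCCCCOc1ccc(C[C@H]2C(=O)OC[C@@H]2Cc2ccccc2)cc1` has not been measured. It differs from compound 3 by propyl in place of hydrogen on a saturated chain carbon, four bonds along the chain from an oxygen on an aromatic ring, the same change as between compound 1 and compound 2, at the same place. The change occurs only twice among these compounds, once measured, so its carry-over to the second core rests on a single observation.

The step from compound 3 to compound 4 is expected to be a 3.5-fold higher number from compound 3 to compound 4 (0.54 log units; beyond the scatter), because compound 2 showed a 3.8-fold higher number from compound 1 to compound 2 (0.57 log units; beyond the scatter). Compound 4 is therefore estimated at 80000 nM in this assay, with a likely range from 35000 nM to 180000 nM.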

Compound 4, half-maximal effective concentration: > 100000 nM
Compound 4: only a limit was reported; the forecaster's own chance of this, stated with the estimate: 15%; at least 1.2-fold (0.09 log units) between middle value and limit.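

In this assay compound 4 gives > 100000 nM, which is a limit of the assay and not a number. On the second core, propyl in place of hydrogen on the saturated chain carbon gives an at least 4.3-fold higher number from compound 3 to compound 4 (0.63 log units; beyond the scatter), so the direction seen on the first core recurs, and the two steps can be set side by side: the same change on two cores in this assay, a 3.8-fold higher number (0.57 log units; beyond the scatter) from compound 1 to compound 2 and an at least 4.3-fold higher number (0.63 log units; beyond the scatter) from compound 3 to compound 4; the limit leaves it open whether they differ. This supports carrying the direction of the change across these two cores, but with one pair on each core it does not show that the size of the step carries over, nor how far the step on the second core extends past the limit.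

The compounds shown leave open how chains between butyl and heptyl, such as pentyl or hexyl, behave on either core, and whether the number rises evenly with chain length. They also leave open what a chain ending in an amine or a carboxylic acid would give at this place in this assay.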